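Aryl exchange from compound 2 to compound 3

The source may report more compounds than this note shows. Statements on the series, on what has been measured and on what is new or still open speak of the compounds shown alone.

Measured so far in a functional assay on FM3A cells (Mus musculus) for antiproliferative activity (on this read-out lower numbers stand for stronger inhibition and higher numbers for weaker inhibition), with these values:
- compound 1 `COc1ccc(-c2cc(N)c(C(=O)c3cc(OC)c(OC)c(OC)c3)s2)cc1OC` gives 72 nM
- compound 2 `COc1cc(C(=O)c2sc(-c3ccc(Cl)cc3)cc2N)cc(OC)c1OC` gives 90 nM

Among the compounds with values here, compound 2 lies within the scatter of compound 1, the only other measured compound. Compound 3 `COc1cc(C(=O)c2sc(-c3cccc([N+](=O)[O-])c3)cc2N)cc(OC)c1OC` is not yet measured. It carries 3-nitrophenyl in place of 4-chlorophenyl on an aromatic carbon next to the ring sulfur.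

Within the data shown here, one measured step bears on this change: a 1.3-fold higher number from compound 1 to compound 2 (0.10 log units; within the scatter) for 4-chlorophenyl in place of 3,4-dimethoxyphenyl on that same carbon. That step stays within the scatter. Among the measured compounds shown here, no compound with a nitro group has been measured, so the evidence is thin. No shift beyond the scatter is expected in this assay in either direction. The step expected is a 1.1-fold higher number from compound 2 to compound 3 (0.05 log units; within the scatter) on this reasoning. For compound 3 the estimate is 100 nM with an expected range from 30 nM to 330 nM as its bounds.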

Compound 3, half-maximal inhibitory concentration: 17 nM
Compound 3: the middle estimate sits 5.9-fold (0.77 log units) above what was measured; the whole stated range lies above it.
By their numbers in this assay, from the lowest: compound 3; then compounds 1 and 2 (each within the scatter of the next).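

The aryl group on the aromatic carbon next to the ring sulfur does affect the read-out in this assay. Within the data shown here, the exchange of 4-chlorophenyl for 3-nitrophenyl gives the first step beyond the scatter at this carbon (a 5.3-fold lower number from compound 2 to compound 3 (0.72 log units; beyond the scatter)), and the exchange of 3,4-dimethoxyphenyl for 3-nitrophenyl points the same way (a 4.2-fold lower number from compound 1 to compound 3 (0.63 log units; beyond the scatter)), whereas the earlier step between those two aryl groups suggested that this position tolerated exchange. Nothing at hand explains why 3-nitrophenyl stands apart from the other two aryl groups.

As far as these compounds go, whether the shift belongs to the nitro group itself or to its place on the phenyl ring stays open, as both differ at once in these compounds. An amine or a nitrile on that phenyl ring would show whether the shift is specific to the nitro group.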